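The compounds below may be only part of what the source reports. "The series", "measured", "known", "first", "only" and "open" are said of these compounds alone.

Measured in a functional assay on A-375 cells (Homo sapiens) for inhibition, read by MTT assay, with a stated time of 4 days; a lower number here means a stronger inhibitor, a higher number a weaker inhibitor:
- compound 1 `CN1C[C@@H]2C[C@H]1CN2c1c(F)cc(-c2ccnc3c(-c4cccc5[nH]ncc45)c(-c4ccncc4)nn23)cc1F`: 1250 nM
- compound 2 `CN1C[C@@H]2CC[C@H]1CN2c1ccc(-c2ccnc3c(-c4cccc5[nH]ncc45)c(-c4ccncc4)nn23)cc1`: 185 nM
- compound 3 `CN1C[C@@H]2CC[C@H]1CN2c1ccc(-c2ccnc3c(-c4cccc5[nH]ncc45)c(-c4ccncc4)nn23)c(F)c1`: 118 nM

Compound 2 has the second highest number of the three. It lies within the scatter of compound 3, and compound 1 reads clearly higher.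

Compound 4 `c1cc(-c2c(-c3ccncc3)nn3c(-c4ccc(CN5C[C@@H]6C[C@H]5CN6)cc4)ccnc23)c2cn[nH]c2c1` follows from compound 2 by a group of 8 heavy atoms (6 carbon, 2 nitrogen; 2 five-membered non-aromatic rings with 1 hetero atom each) in place of a group of 9 heavy atoms (7 carbon, 2 nitrogen; one six-membered non-aromatic ring with 1 hetero atom, one six-membered non-aromatic ring with 2 hetero atoms), on an aromatic carbon. Within the data shown here, the only measured step, a 1.6-fold lower number from compound 2 to compound 3 (0.20 log units; within the scatter), is a fluoro in place of hydrogen on an aromatic carbon, so it is a different change. Compound 1 differs from compound 2 in more than one place. Among the measured compounds shown here, no measured pair isolates this replacement, so no shift beyond the scatter is expected in this assay.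

The expected step is a 1.2-fold higher number from compound 2 to compound 4 (0.08 log units; within the scatter).

For compound 4 the estimated value is 220 nM, with an expected range of 70 nM to 700 nM.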

Compound 4, half-maximal inhibitory concentration: 9480 nM
Compound 4: middle estimate off by 43-fold (1.63 log units), on the low side; the whole stated range lies below it.
By their numbers in this assay, from the lowest: compounds 3 and 2 (each within the scatter of the next); then compound 1; then compound 4.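

In this assay, a 51-fold higher number from compound 2 to compound 4 (1.71 log units; beyond the scatter) shows that this aromatic carbon, para to a large group, does not tolerate every bicyclic amine group. The fluoro step had given no such sign, and here two five-membered non-aromatic rings replacing two six-membered ones, with a hydrogen-bond donor entering, go with a large loss. No measured evidence bears on the origin of this step.

Ring size and donor count change together here, so their contributions remain unseparated. A morpholine or a dimethylamino group at this carbon would show how simpler groups fare.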